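A few compounds are considered here, and "the series" means these few. Any claim that something is new, unique, unknown or untested is made for them only; others in the source may bear on it.

Measured in a functional assay on HepG2 cells (Homo sapiens) for cytotoxicity, read by MTT assay, with a stated time of 72 h (on this read-out lower numbers stand for stronger inhibition and higher numbers for weaker inhibition), so far:

- Compound 1 `CNC(=O)c1cc(Oc2ccc(C3=NNC(c4ccc(F)cc4Cl)C3)cc2)ccn1` gives 11500 nM
- Compound 2 `CNC(=O)c1cc(Oc2ccc(C3=NNC(c4cccc([N+](=O)[O-])c4)C3)cc2)ccn1` gives 26500 nM
- Compound 3 `CNC(=O)c1cc(Oc2ccc(C3=NNC(c4ccccc4)C3)cc2)ccn1` gives 1500 nM

Compound 3 at 1500 nM stands lowest of the three, making it the most potent so far. Compound 4 `CNC(=O)c1cc(Oc2ccc(C3=NNC(c4ccc(F)cc4)C3)cc2)ccn1` differs from it by fluoro in place of hydrogen on an aromatic carbon, para to a large group, counted as fluoro in place of hydrogen on an aromatic carbon and nothing more. Among the measured compounds shown here, two measured steps bear on this. Plain phenyl gave the lower number both times, in a 7.7-fold lower number from compound 1 to compound 3 (0.88 log units; beyond the scatter) and in an 18-fold lower number from compound 2 to compound 3 (1.25 log units; beyond the scatter) as well. The first is the closer guide, since 2-chloro-4-fluorophenyl also holds a fluoro, though together with a chloro. A single fluoro is a smaller change, so a smaller upward step is expected, a 2.3-fold higher number from compound 3 to compound 4 (0.37 log units; beyond the scatter) by estimate. The estimated value of compound 4 in this assay is 3500 nM (range 1200 nM to 11000 nM).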

Compound 4, half-maximal inhibitory concentration: 5280 nM
For compound 4 the middle estimate is 1.5-fold (0.18 log units) below the measured one, and the stated range covers the measured number.
By their numbers in this assay, from the lowest: compound 3; then compound 4; then compound 1; then compound 2.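

A single fluoro on the phenyl ring is enough to shift the result in this assay, a 3.5-fold higher number from compound 3 to compound 4 (0.55 log units; beyond the scatter), so even a one-atom change at this place counts. The chloro adds to this, since removing it gives a 2.2-fold lower number from compound 1 to compound 4 (0.34 log units; beyond the scatter), and 4-fluorophenyl also compares well with nitrophenyl, a 5.0-fold lower number from compound 2 to compound 4 (0.70 log units; beyond the scatter). Nothing available explains why these groups differ. Going by these compounds, whether any group on this ring can give a lower number than compound 3 remains open. A methoxy or an amine at this place would help to settle that.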